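A Dimethoxy Swap on the Carbonyl Carbon

The compounds below may be only part of what the source reports. "The series", "measured", "known", "first", "only" and "open" are said of these compounds alone.

Compound 1 `O=C1c2ccccc2C(=O)N1CCOC(=S)N(C(=O)c1cc(F)ccc1F)c1ccc(Cl)cc1` gives 54000 nM
Compound 2 `Cc1ccc(N(C(=O)c2cc(F)ccc2F)C(=S)OCCN2C(=O)c3ccccc3C2=O)cc1` gives 62000 nM

In an ADME assay on MT4 cells (Homo sapiens) for cytotoxicity, read by MTT assay (on this read-out higher numbers stand for lower toxicity in this test and lower numbers for higher toxicity in this test), compound 2 gives 62000 nM and so stands level with compound 1 within the scatter. Compound 3 `COc1cccc(OC)c1C(=O)N(C(=S)OCCN1C(=O)c2ccccc2C1=O)c1ccc(C)cc1` differs from compound 2 by 2,6-dimethoxyphenyl in place of 2,5-difluorophenyl on a carbonyl carbon with 2,6-dimethoxyphenyl in place of 2,5-difluorophenyl on a carbonyl carbon. Going by the values given here, the only measured step is a 1.1-fold higher number from compound 1 to compound 2 (0.06 log units; within the scatter) and it concerns a different change, methyl in place of chloro on an aromatic carbon. This change itself has not been measured, so no step beyond the scatter is expected in this assay and the expected step is a 1.2-fold lower number from compound 2 to compound 3 (0.09 log units; within the scatter) with wide uncertainty. Compound 3 is expected at 50000 nM with 18000 nM to 100000 nM as its estimated range.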

Compound 3, half-maximal cytotoxic concentration: 36000 nM
Beside the measured number, compound 3's estimate is 1.4-fold (0.14 log units) above it, within the range that was stated.
By their numbers in this assay, from the lowest: compounds 3, 1 and 2 (each within the scatter of the next).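

In this assay the exchange of 2,5-difluorophenyl for 2,6-dimethoxyphenyl on a carbonyl carbon gives a 1.7-fold lower number from compound 2 to compound 3 (0.24 log units; within the scatter) and so stays within the scatter. Among these compounds, then, neither this exchange nor the earlier one of chloro for methyl separates the compounds in this test. No evidence at hand bears on this result.

From the compounds shown here alone, whether a pyridine ring or a phenyl carrying a carboxylic acid on this carbonyl carbon would produce a step beyond the scatter remains open. So does whether 2,6-dimethoxyphenyl behaves alike when chloro stands in place of methyl.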